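Sulfo Replaces Hydrogen on the Amine of Compound 1

The source may report more compounds than this note shows. Statements on the series, on what has been measured and on what is new or still open speak of the compounds shown alone.

Within the data shown here, compound 1 `Cc1cc(-c2nc3ccccc3s2)ccc1N` is the only compound here with a plain number in a physicochemical assay for lipophilicity, at pH 7.4; on this read-out higher numbers stand for higher lipophilicity and lower numbers for lower lipophilicity: compound 1 gives 2.51. Compound 2 `Nc1ccc(-c2nc3ccccc3s2)cc1Br` in this assay reaches only a limit of the assay, > 2.8, not a number. The reach of the data is marked by the limit of > 2.8 in this assay, at which 1 of the 2 values shown sits. Among the measured compounds shown here, the single measured step, a number at least 0.29 log units higher from compound 1 to compound 2 (that floor lies within the scatter), concerns a different change from the one now followed. Compound 3 `Cc1cc(-c2nc3ccccc3s2)ccc1NS(=O)(=O)O` differs from compound 1 by sulfo in place of hydrogen on a nitrogen on an aromatic ring. For the measured compounds named here, no measured step covers this change, so the expectation rests on the structural change alone. Compound 3 is expected to give -0.5, between -1.5 and 0.5, an estimated step of a number 3.01 log units lower from compound 1 to compound 3 (beyond the scatter), with a fair chance that only a limit is reported.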

Compound 3, distribution coefficient: < 3
Compound 3 was reported as a limit; the forecaster's own chance of this, stated with the estimate: 30%; the middle value does not contradict the limit.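

Among these compounds, compound 3 is reported only as a limit, and no step from compound 1 to compound 3 can be read from it. The compounds shown leave open how far sulfo in place of hydrogen on the nitrogen shifts the number in this assay.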